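Notes on a series sitting at the assay limit

This account rests on a few compounds, and the source may have more. Where it says the series, first, only, none or still open, it means among the compounds named here.

Measured so far:
compound 1, `O=C(Nc1ccc(-c2noc(-c3cccc(NS(=O)(=O)c4ccccc4)c3)n2)c(Cl)c1)c1cccnc1`: in a functional assay on MDA-MB-231 cells (Homo sapiens) for antiproliferative activity, read by MTT assay, with a stated time of 72 h (a higher number here means a weaker inhibitor, a lower number a stronger inhibitor), compound 1 gives > 10000 nM, which is a limit.
compound 2, `COc1cccc(S(=O)(=O)Nc2cccc(-c3nc(-c4ccc(NC(=O)c5cccnc5)cc4Cl)no3)c2)c1`: in this assay compound 2 gives > 10000 nM, also a limit.
compound 3, `COc1cc(NC(=O)c2cccnc2)ccc1-c1noc(-c2cccc(NS(=O)(=O)c3ccc(NC(C)=O)cc3)c2)n1`: in this assay compound 3 gives > 10000 nM, again a limit.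

Compound 1 therefore stands only at a limit, and the two further values are limits too. Going by the values given here, the only single-point step, a step that the two limits leave unreadable from compound 1 to compound 2, cannot be read, because of the limit of > 10000 nM in this assay, at which 3 of the 3 values shown sit. Compound 4, `CCN(CC)C(=O)Nc1ccc(S(=O)(=O)Nc2cccc(-c3nc(-c4ccc(NC(=O)c5cccnc5)cc4Cl)no3)c2)cc1`, differs from compound 1 by (diethylcarbamoyl)amino in place of hydrogen on an aromatic carbon. Among the compounds with values here, compound 3 carries an amide-substituted sulfonyl ring and still sits at the limit, so no measured step argues for a gain. Compound 4 is expected to give 15000 nM, with a range from 5000 nM to 50000 nM. The step that the limit leaves unreadable from compound 1 to compound 4 is expected to be nominal only, most probably reported as a limit again.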

Compound 4, half-maximal inhibitory concentration: 8700 nM
Compound 4: middle estimate off by 1.7-fold (0.24 log units), on the high side, and the stated range covers the measured number.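

With (diethylcarbamoyl)amino on this aromatic carbon, para to a large group, compound 4 is the first compound shown to give a number rather than a limit in this assay (8700 nM). The change is readable as an at least 1.1-fold lower number from compound 1 to compound 4 (0.06 log units; that floor lies within the scatter), so this position accepts the group, but a real gain is not established. The other steps cannot be read: the limit of > 10000 nM in this assay, at which 3 of the 4 values shown sit.

From the compounds shown here alone, it remains open whether the ethyl groups matter or the carbonyl-bearing nitrogen alone suffices. A plain amine or (dimethylcarbamoyl)amino on this carbon would separate the two.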